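The source may report more compounds than this note shows. Statements on the series, on what has been measured and on what is new or still open speak of the compounds shown alone.

Measured in a functional assay on PC-9 cells (Homo sapiens) for inhibition, read by MTT assay, with a stated time of 48 h, tested at 10 uM; on this read-out lower numbers stand for less inhibition and higher numbers for more inhibition at the one concentration tested (going by the name of the read-out):
compound 1 `COc1ccc(Br)cc1Nc1cc(NC(=O)Nc2c(Cl)cccc2Cl)ncn1` gives 69%;
compound 2 `COc1ccc(OC)c(Nc2cc(NC(=O)Nc3c(Cl)cccc3Cl)ncn2)c1` gives 95%.

Compound 1 stands lowest of the two; its nearest neighbour is compound 2, with a number 26 percentage points higher from compound 1 to compound 2 (beyond the scatter). Compound 3 `O=C(Nc1cc(Nc2ccc(F)c(Cl)c2)ncn1)Nc1c(Cl)cccc1Cl` differs from compound 1 in one place: 3-chloro-4-fluorophenyl in place of 5-bromo-2-methoxyphenyl on a nitrogen on an aromatic ring. Going by the values given here, no measured step covers this exchange; the single step from compound 1 to compound 2 concerns a different group and gives no direct guide. With only that to go on, no step beyond the scatter is expected in this assay for compound 3, estimated at 68% (range 35% to 92%), a step of a number 1 percentage points lower from compound 1 to compound 3 (within the scatter) from compound 1.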

Compound 3, a percentage reported as inhibition, at one concentration (the size of the read-out at that concentration, not a potency): 91.1%
Beside the measured number, compound 3's estimate is 23.1 percentage points below it; the range from low to high includes it.
By their numbers in this assay, from the lowest: compound 1; then compounds 3 and 2 (each within the scatter of the next).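

In this assay, going by these compounds alone, 3-chloro-4-fluorophenyl in place of 5-bromo-2-methoxyphenyl on the nitrogen gives a number 22.1 percentage points higher from compound 1 to compound 3 (beyond the scatter) and thus a gain at this position from a full exchange of the group, not only from the single swap seen before. The entering group has no methoxy, so compound 3 shows that a methoxy on this ring is not required for a number of this size. Nothing at hand explains this step.

On these data alone, whether an amine or a carboxylic acid on this ring would keep the number stays open. As each number comes from one concentration, the potency of these compounds also stays open.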